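The source may report more compounds than this note shows. Statements on the series, on what has been measured and on what is new or still open speak of the compounds shown alone.

Compound 1 `C=CCOc1ccc2c(NCCN(C)C)ccnc2c1` gives 930 nM in a functional assay on NCI-H1650 cells (Homo sapiens) for cytotoxicity, read by MTT assay, with a stated time of 48 h; a lower number here means a stronger inhibitor, a higher number a weaker inhibitor.
Compound 2 `CN(C)CCCNc1ccnc2cc(OCc3ccc(F)cc3)ccc12` gives 940 nM.
Compound 3 `CCOc1ccc2c(NCCN(C)C)ccnc2c1` gives 3490 nM.

Compound 3 stands highest of the three, lying beyond the scatter from compound 2 and from compound 1. Among the compounds with values here, the one measured step, a 3.8-fold higher number from compound 1 to compound 3 (0.57 log units; beyond the scatter), concerns the ether side and not the chain. Compound 4 `CCOc1ccc2c(NCCCN(C)C)ccnc2c1` differs from compound 3 by (dimethylamino)methyl in place of dimethylamino on a saturated chain carbon, two bonds along the chain from a nitrogen on an aromatic ring. Within the data shown here, no measured step bears on this change directly. Compound 2 carries the longer chain yet also another ether group, so its closeness to compound 1 cannot be credited to the chain alone. Compound 4 is therefore expected to give 3000 nM (range 1000 nM to 9000 nM), a step of a 1.2-fold lower number from compound 3 to compound 4 (0.07 log units; within the scatter) that is estimated not to exceed the scatter.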

Compound 4, half-maximal inhibitory concentration: 3830 nM
Compound 4: the middle estimate sits 1.3-fold (0.11 log units) below what was measured; low and high end bracket the measured number.
By their numbers in this assay, from the lowest: compounds 1 and 2 (each within the scatter of the next); then compounds 3 and 4 (each within the scatter of the next).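

In this assay, (dimethylamino)methyl in place of dimethylamino, on a saturated chain carbon two bonds along the chain from a nitrogen on an aromatic ring, gives a 1.1-fold higher number from compound 3 to compound 4 (0.04 log units; within the scatter), so this chain change stays within the scatter. On the ether side, the longer chain also shows a change beyond the scatter, with methyl in place of 4-fluorophenyl giving a 4.1-fold higher number from compound 2 to compound 4 (0.61 log units; beyond the scatter). No evidence is available on what lies behind either step.

A still longer chain, or a pyrrolidine in place of the dimethylamino end, remains open, since the compounds shown contain neither.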